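The source may hold more compounds than are shown below. What is called first, only, known or untested is meant among the compounds shown, and "the series" means these compounds.

Three members of the series have been tested so far. Compound 1, `CC(C)=CCOc1ccc2c(c1)OC(c1cccc(Br)c1)CC2=O`, gives 5280 nM in a functional assay; on this read-out lower numbers stand for stronger inhibition and higher numbers for weaker inhibition. Compound 2, `CC(C)=CCOc1ccc2c(c1)OC(c1ccc(Br)cc1)CC2=O`, gives 8120 nM in this assay; the change 4-bromophenyl in place of 3-bromophenyl on a saturated ring carbon produced a 1.5-fold higher number from compound 1 to compound 2 (0.19 log units; within the scatter). Compound 3, `CC(C)=CCOc1cc(O)c2c(c1)OC(c1cccc(Br)c1)CC2=O`, gives 4040 nM in this assay, and here the change hydroxy in place of hydrogen on an aromatic carbon produced a 1.3-fold lower number from compound 1 to compound 3 (0.12 log units; within the scatter). The numbers for compound 2 and compound 3 also lie within the scatter of one another, so no ranking of compound 1, compound 2 and compound 3 can be drawn from these data.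

Compound 4, `CC(C)=CCOc1cc(O)c2c(c1)OC(c1ccc(Br)cc1)CC2=O`, is not yet measured. It differs from compound 3 by 4-bromophenyl in place of 3-bromophenyl on a saturated ring carbon, the same change that separates compound 1 from compound 2; the two cores on which the change is made differ by hydroxy in place of hydrogen on an aromatic carbon. Since the same change gave a 1.5-fold higher number from compound 1 to compound 2 (0.19 log units; within the scatter), a step of similar size is expected in this assay, namely a 1.5-fold higher number from compound 3 to compound 4 (0.17 log units; within the scatter). The estimate for compound 4 in this assay is 6000 nM, with the likely range running from 3500 nM to 10500 nM.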

Compound 4, half-maximal inhibitory concentration: 2770 nM
Compound 4: the middle estimate sits 2.2-fold (0.34 log units) above what was measured, outside the stated range (below it).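

In this assay, 4-bromophenyl in place of 3-bromophenyl on a saturated ring carbon gives a 1.5-fold lower number from compound 3 to compound 4 (0.16 log units; within the scatter), and set beside the same change on the core of compound 1, it shows no difference between cores that can be read: the same change on two cores in this assay, a 1.5-fold higher number (0.19 log units; within the scatter) from compound 1 to compound 2 and a 1.5-fold lower number (0.16 log units; within the scatter) from compound 3 to compound 4, 2.2-fold (0.35 log units) apart, within the scatter of two such steps

Hydroxy in place of hydrogen on an aromatic carbon gives a 2.9-fold lower number from compound 2 to compound 4 (0.47 log units; beyond the scatter), the only step in the series so far that lies beyond the scatter, yet its gap to the same change on the other core stays within the scatter: the same change on two cores in this assay, a 1.3-fold lower number (0.12 log units; within the scatter) from compound 1 to compound 3 and a 2.9-fold lower number (0.47 log units; beyond the scatter) from compound 2 to compound 4, 2.2-fold (0.35 log units) apart, within the scatter of two such steps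

These four compounds therefore give no evidence that either change depends on the core, but with one pair of steps per change they do not prove that either carries over unchanged.

Still open, from the compounds shown here alone, is whether an amine or a methoxy group in place of the bromine would shift the number in this assay. Also open, going by these compounds, is what a longer chain would do in place of the alkenyl chain on the ether oxygen.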